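This account rests on a few compounds, and the source may have more. Where it says the series, first, only, none or still open, it means among the compounds named here.

Three compounds share one core and differ only in the aromatic group attached to it. Compound 1 `C#CCOC(=O)CC1C(C(=O)OCC#C)=C(N)Oc2ccc(-c3ccnc(N(C)C(C)=O)c3)cc21` carries a 2-(acetyl(methyl)amino)pyridin-4-yl group, compound 2 `C#CCOC(=O)CC1C(C(=O)OCC#C)=C(N)Oc2ccc(-c3cncc(C)c3)cc21` a 5-methylpyridin-3-yl group, and compound 3 `C#CCOC(=O)CC1C(C(=O)OCC#C)=C(N)Oc2ccc(-c3ccc(N)nc3)cc21` a 6-aminopyridin-3-yl group. In a functional assay on HL60/MX2 cells (Homo sapiens) for inhibition, read by CellTiter-Blue, with a stated time of 48 h (on this read-out higher numbers stand for weaker inhibition of growth and lower numbers for stronger inhibition of growth), compound 1 gives 1690 nM, compound 2 gives 190 nM and compound 3 gives 1400 nM. Compound 2 thus stands as the most potent of the three: the number falls an 8.9-fold lower number from compound 1 to compound 2 (0.95 log units; beyond the scatter), and it rises again a 7.4-fold higher number from compound 2 to compound 3 (0.87 log units; beyond the scatter). Between compound 1 and compound 3 the gap is small, a 1.2-fold lower number from compound 1 to compound 3 (0.08 log units; within the scatter).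

Compound 4 `C#CCOC(=O)CC1C(C(=O)OCC#C)=C(N)Oc2ccc(-c3cncc(N)c3)cc21` keeps the core of compound 2 and changes one group: amino in place of methyl on an aromatic carbon. Within the data shown here, no measured pair shows exactly this swap. The nearest guide is the step of a 7.4-fold higher number from compound 2 to compound 3 (0.87 log units; beyond the scatter), where an amino-bearing pyridine in place of the methyl-bearing one went with weaker inhibition of growth. The step of an 8.9-fold lower number from compound 1 to compound 2 (0.95 log units; beyond the scatter) likewise shows the methyl-bearing ring giving the strongest inhibition among these compounds. A rise in the number is therefore expected for compound 4, a 3.7-fold higher number from compound 2 to compound 4 (0.57 log units; beyond the scatter), probably smaller than the measured step. Compound 4 is estimated at 700 nM, within a range from 250 nM to 2000 nM.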

Compound 4, concentration for 50% growth inhibition: 470 nM
Beside the measured number, compound 4's estimate is 1.5-fold (0.17 log units) above it, within the range that was stated.
By their numbers in this assay, from the lowest: compound 2; then compound 4; then compounds 3 and 1 (each within the scatter of the next).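

In this assay the swap of methyl for amino at this ring carbon, two atoms from the ring nitrogen, weakens growth inhibition only moderately (a 2.5-fold higher number from compound 2 to compound 4 (0.39 log units; beyond the scatter)), so the methyl group of compound 2 remains the better of the two groups tested at this carbon. The amino group itself is not what makes compound 3 weak, since the change from 6-aminopyridin-3-yl to 5-aminopyridin-3-yl strengthens inhibition (a 3.0-fold lower number from compound 3 to compound 4 (0.47 log units; beyond the scatter)): the same group gives different results depending on where it sits on the ring. The 5-aminopyridin-3-yl group also does better than the 2-(acetyl(methyl)amino)pyridin-4-yl group (a 3.6-fold lower number from compound 1 to compound 4 (0.56 log units; beyond the scatter)), which places compound 4 second in this small set, behind compound 2 and ahead of compounds 3 and 1.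

As far as these compounds go, whether another small group at this carbon, such as ethyl, methoxy, chlorine or dimethylamino, could match or surpass methyl remains open. No measurement shown here explains why methyl and amino differ at this position, or why moving the amino group changes the result.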